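This account rests on a few compounds, and the source may have more. Where it says the series, first, only, none or still open, it means among the compounds named here.

Compound 3 `CC(Oc1ccc(-c2ccccc2)cc1)C(=O)Cn1nnc(-c2ccc(Cl)cc2)n1` gives 6.1 in a physicochemical assay for lipophilicity, read by HPLC, tested at 5 mM (on this read-out higher numbers stand for higher lipophilicity and lower numbers for lower lipophilicity), the lowest of the two numbers shown. Its nearest neighbour is compound 2 `CC(Oc1ccc(Oc2ccc(C(F)(F)F)cc2)cc1)C(=O)Cn1nnc(-c2ccc(Cl)cc2)n1`, which gives 7 in this assay. Compound 1 `CCCCCCCCc1ccc(OC(C)C(=O)Cn2nnc(-c3ccc(Cl)cc3)n2)cc1` reaches only a limit of the assay, reported as > 8. The measured steps were a number at least 1.00 log units lower from compound 1 to compound 2 (beyond the scatter), a number at least 1.90 log units lower from compound 1 to compound 3 (beyond the scatter) and a number 0.90 log units lower from compound 2 to compound 3 (beyond the scatter), and each of them alters the group on the other aromatic ring, not the part touched here. Compound 4 `COC(=O)c1ccc(-c2nnn(CC(=O)C(C)Oc3ccc(-c4ccccc4)cc3)n2)cc1` differs from compound 3 by methoxycarbonyl in place of chloro on an aromatic carbon. Within the data shown here, no measured step covers that change, so the expectation rests on the change itself: a modest fall is expected, a number 0.80 log units lower from compound 3 to compound 4 (beyond the scatter). Compound 4 is therefore estimated at 5.3, between 4.7 and 5.9.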

Compound 4, partition coefficient: 5.4
Compound 4: middle estimate off by 0.10 log units, on the low side, within the range that was stated.
By their numbers in this assay, from the lowest: compound 4; then compound 3; then compound 2. At a limit, above all of these: compound 1.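

Methoxycarbonyl in place of chloro, para to a large group, is the first change shown at this end of the molecule, and in this assay it gives a number 0.70 log units lower from compound 3 to compound 4 (beyond the scatter). Among these compounds, all the earlier steps altered the group on the other aromatic ring, so this position is now seen to shift the read-out as well. Nothing measured here gives a reason for this step. The compounds shown leave open how a carboxylic acid or an amine would read at this place, and whether the same change gives a similar step with 4-(trifluoromethyl)phenoxy on the other ring.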